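Lipophilicity of Cinnamoyl Amides and Esters with Amine-Bearing Chains

The source may report more compounds than this note shows. Statements on the series, on what has been measured and on what is new or still open speak of the compounds shown alone.

Compound 1 `COc1cc(/C=C/C(=O)Nc2ccccc2)ccc1OCCCCCCN1CCCCC1` carries an anilide and a chain ending in a piperidin-1-yl group; in a physicochemical assay for lipophilicity, using the shake flask method, measured as octanol-water partition, at pH 7.4 (a higher number here means a more lipophilic compound, a lower number a more polar compound), compound 1 gives 1.77. Compound 2 `CCN(CC)CCCCCCCCOc1ccc(/C=C/C(=O)Nc2ccccc2)cc1OC` differs from it by 2-(diethylamino)ethyl in place of piperidin-1-yl on a saturated chain carbon, six bonds along the chain from an oxygen on an aromatic ring, and in this assay compound 2 gives 1.75, a step of a number 0.02 log units lower from compound 1 to compound 2 (within the scatter). Compound 3 `CCOC(=O)/C=C/c1ccc(OCCCCCCN2CCCCC2)c(OC)c1` has a different core, differing from compound 1 by ethoxy in place of anilino on a carbonyl carbon; in this assay compound 3 gives 1.81, a step of a number 0.04 log units higher from compound 1 to compound 3 (within the scatter). All three measured values lie within the usual scatter of one another.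

Compound 4 `CCOC(=O)/C=C/c1ccc(OCCCCCCCCN(CC)CC)c(OC)c1` has not been measured in this assay. It differs from compound 3 by 2-(diethylamino)ethyl in place of piperidin-1-yl on a saturated chain carbon, six bonds along the chain from an oxygen on an aromatic ring, the same change made from compound 1 to compound 2, at the same place. Because that change gave a number 0.02 log units lower from compound 1 to compound 2 (within the scatter), a step of about a number 0.02 log units lower from compound 3 to compound 4 (within the scatter) is expected from compound 3 to compound 4. Compound 4 is therefore expected to give 1.79. The estimate for compound 4 is expected to fall between 1.5 and 2.1.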

Compound 4, partition coefficient: 1.98
Compound 4: the middle estimate sits 0.19 log units below what was measured; the measured number falls inside the stated range.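

In this assay the change from piperidin-1-yl to 2-(diethylamino)ethyl gives a number 0.17 log units higher from compound 3 to compound 4 (within the scatter) on the core of compound 3 and a number 0.02 log units lower from compound 1 to compound 2 (within the scatter) on the core of compound 1, so on neither core does the step leave the scatter. The other change in this square, ethoxy in place of anilino, likewise gives a number 0.23 log units higher from compound 2 to compound 4 (within the scatter) with the 2-(diethylamino)ethyl chain and a number 0.04 log units higher from compound 1 to compound 3 (within the scatter) with the piperidin-1-yl chain, which shows that the amine change carries from one core to the other without a step beyond the scatter, but does not show that it has the same size on both cores or any real size at all. Nothing shown here bears on why the numbers fall as they do.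

The four compounds cover only two chain ends and two carbonyl substituents. From the compounds shown here alone, it stays open whether the same agreement would hold for a morpholine at the chain end, a shorter chain, or a carboxylic acid in place of the ethyl ester.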